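The source may hold more compounds than are shown below. What is called first, only, known or untested is meant among the compounds shown, and "the series" means these compounds.

Of the compounds shown here, three sharing one core have been measured in a functional assay on HepG2 cells (Homo sapiens) for cytotoxicity, read by MTT assay, with a stated time of 48 h (a lower number here means a stronger inhibitor, a higher number a weaker inhibitor), and they differ only in the group on a carbon with a double bond to nitrogen. Compound 1 (`O=C(CSc1nnc(-c2ccncc2)o1)N/N=C/c1ccc(Cl)cc1`), with 4-chlorophenyl, gives 15700 nM in this test. Compound 2 (`COc1cccc(/C=N/NC(=O)CSc2nnc(-c3ccncc3)o2)c1`), with 3-methoxyphenyl, gives 9170 nM in the same test. Compound 3 (`O=C(CSc1nnc(-c2ccncc2)o1)N/N=C/c1cc(Cl)cc(Cl)c1O`), with 3,5-dichloro-2-hydroxyphenyl, gives 3260 nM as the lowest of the three numbers, and its steps to both others lie beyond the scatter.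

Compound 4 (`O=C(CSc1nnc(-c2ccncc2)o1)N/N=C/C=C/c1ccccc1`) is still unmeasured, and it departs from compound 3 as follows (2-phenylethenyl in place of 3,5-dichloro-2-hydroxyphenyl on a carbon with a double bond to nitrogen): 2-phenylethenyl stands in place of 3,5-dichloro-2-hydroxyphenyl. Among the compounds with values here, two measured steps bear on this change, since each ends at the group that leaves: a 4.8-fold lower number from compound 1 to compound 3 (0.68 log units; beyond the scatter) and a 2.8-fold lower number from compound 2 to compound 3 (0.45 log units; beyond the scatter) are both modest. The remaining step is a 1.7-fold lower number from compound 1 to compound 2 (0.23 log units; within the scatter) and separates the other two groups by no real margin. Within the data shown here, no measured compound carries 2-phenylethenyl, so the evidence is indirect. The move expected in this assay is a modest one towards a higher number, about the size of a 2.8-fold lower number from compound 2 to compound 3 (0.45 log units; beyond the scatter) in reverse. The estimated step is a 2.8-fold higher number from compound 3 to compound 4 (0.44 log units; beyond the scatter) on this reasoning. Compound 4 is therefore expected at 9000 nM within a range from 3000 nM to 25000 nM for now.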

Compound 4, half-maximal inhibitory concentration: 7420 nM
Compound 4: middle estimate off by 1.2-fold (0.08 log units), on the high side; the measured number falls inside the stated range.
By their numbers in this assay, from the lowest: compound 3; then compounds 4, 2 and 1 (each within the scatter of the next, the first and the last beyond it).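

Moving from the ring-bearing groups to 2-phenylethenyl on the carbon with a double bond to nitrogen gives a 2.3-fold higher number from compound 3 to compound 4 (0.36 log units; beyond the scatter) in this assay and shows that this position accepts a group with a double bond outside aromatic rings. That group has no hydrogen-bond donor or acceptor and no chlorine, yet the result is a 1.2-fold lower number from compound 2 to compound 4 (0.09 log units; within the scatter) and, against the 4-chlorophenyl group, a 2.1-fold lower number from compound 1 to compound 4 (0.33 log units; beyond the scatter). Thus, among these four compounds, 3,5-dichloro-2-hydroxyphenyl alone keeps a number clearly lower than the rest, although the gap to compound 4 is modest, and the phenyl ring need not sit directly on that carbon for the number to stay in the range of compounds 1 and 2.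

The compounds shown leave open whether the double bond of 2-phenylethenyl matters, which a saturated 2-phenylethyl chain would address, whether the hydroxyl or the two chlorines carry the lower number of compound 3, and how an amine or a carboxylic acid on the phenyl ring would read in this test. No measurement given here explains any of these differences, so their cause remains unknown.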